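Swapping a trifluoromethyl for chloro on a urea aryl

The source may hold more compounds than are shown below. What is called first, only, known or untested is meant among the compounds shown, and "the series" means these compounds.

Of the compounds shown here, two have been tested in a functional assay on RXF 393 cells (Homo sapiens) for inhibition, read by sulforhodamine B assay, with a stated time of 48 h, tested at 10 uM; a lower number here means a stronger effect, a higher number a weaker effect of the compound at the concentration tested. Compound 1, `COc1cc(Cl)cc(-c2nn(-c3cccc(NC(=O)c4ccc(Cl)c(Cl)c4)c3)cc2-c2ccncc2)c1`, gives 59.2%. Compound 2, `O=C(Nc1cccc(-n2cc(-c3ccncc3)c(-c3cc(O)cc(Cl)c3)n2)c1)Nc1ccc(Cl)c(C(F)(F)F)c1`, gives -49.5%, the lower of the two numbers and thus the stronger effect, beyond the scatter from compound 1. Compound 3, `O=C(Nc1cccc(-n2cc(-c3ccncc3)c(-c3cc(O)cc(Cl)c3)n2)c1)Nc1ccc(Cl)c(Cl)c1`, is not yet measured. It differs from compound 2 by one change: chloro in place of trifluoromethyl on an aromatic carbon. For the measured compounds named here, no step between measured compounds shows what this change does. The step from compound 2 to compound 3 is expected to be small, a number 9.5 percentage points higher from compound 2 to compound 3 (within the scatter), with no clear direction beyond the scatter. Compound 3 is therefore expected to give about -40%, likely between -85% and 15%.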

Compound 3, a percentage reported as activity, at one concentration (the size of the read-out at that concentration, not a potency): -70.3%
Compound 3: the middle estimate sits 30.3 percentage points above what was measured, within the range that was stated.
By their numbers in this assay, from the lowest: compound 3; then compound 2; then compound 1.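

For the compounds shown here, this is the first direct reading of this position: in this assay, going from 4-chloro-3-(trifluoromethyl)phenyl to 3,4-dichlorophenyl gives a number 20.8 percentage points lower from compound 2 to compound 3 (beyond the scatter). The trifluoromethyl is therefore not required for the strong effect here, since a chloro, with one heavy atom in place of four, keeps it and adds a modest gain. Nothing measured here explains why the number moves this way.

Going by these compounds, whether a bromo, a methyl or a nitrile at this position would push the number lower still remains open. A reading at one concentration also gives the size of the effect, not a potency.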